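The compounds below may be only part of what the source reports. "The series", "measured", "known", "first", "only" and "open" are said of these compounds alone.

Compound 1 `COc1ccc(CN2C(=O)/C(=C/c3cc(C)n(-c4ccc(O)c(C(=O)O)c4)c3C)SC2=S)cc1` carries a 4-methoxyphenyl on a saturated chain carbon bound to an amide-type nitrogen in a ring. In an ADME assay on MT2 cells (Homo sapiens) for cytotoxicity, read by XTT assay, with a stated time of 4 days (on this read-out higher numbers stand for lower toxicity in this test and lower numbers for higher toxicity in this test), compound 1 gives 75300 nM. Compound 2 `Cc1cc(/C=C2\SC(=S)N(Cc3ccc(C(=O)O)cc3)C2=O)c(C)n1-c1ccc(O)c(C(=O)O)c1` gives 105000 nM in this assay, a change of a 1.4-fold higher number from compound 1 to compound 2 (0.14 log units; within the scatter). Compound 3 `Cc1cc(/C=C2\SC(=S)N(Cc3cccc(C(=O)O)c3)C2=O)c(C)n1-c1ccc(O)c(C(=O)O)c1` reaches only > 100000 nM in this assay, which is a limit of the test and not a number. Of the two numbers in this assay, compound 1 has the lowest, with compound 2 nearest.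

Compound 4 `Cc1cc(/C=C2\SC(=S)N(Cc3ccccc3C(F)(F)F)C2=O)c(C)n1-c1ccc(O)c(C(=O)O)c1` differs from compound 1 by 2-(trifluoromethyl)phenyl in place of 4-methoxyphenyl on a saturated chain carbon bound to an amide-type nitrogen in a ring. The measured step that touches the same place is an at least 1.3-fold higher number from compound 1 to compound 3 (0.12 log units; that floor lies within the scatter), and the step of a 1.4-fold higher number from compound 1 to compound 2 (0.14 log units; within the scatter) also changes only a group on that same benzyl; neither moved beyond the scatter. One of the three values sits at the limit of > 100000 nM in this assay, at which 1 of the 3 values shown sits, so the upper end of this assay is partly hidden and a step cannot be read there. On that basis the step expected is a 1.1-fold lower number from compound 1 to compound 4 (0.03 log units; within the scatter), with no movement beyond the scatter in either direction. Compound 4 is therefore estimated to give 70000 nM in this assay, within a range from 30000 nM to 150000 nM.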

Compound 4, half-maximal cytotoxic concentration: 28800 nM
Compound 4: the middle estimate sits 2.4-fold (0.39 log units) above what was measured; measured number below the stated range.
By their numbers in this assay, from the lowest: compound 4; then compounds 1 and 2 (each within the scatter of the next).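

Going by these compounds alone, until now, the readable steps on this benzyl position in this assay all stayed within the scatter, so the position could have seemed indifferent to what it carries; compound 4 is the first case where a change there clearly moves the number: a 2.6-fold lower number from compound 1 to compound 4 (0.42 log units; beyond the scatter). A lower number here stands for higher toxicity in this test, and the same direction appears against the two carboxy compounds, with a 3.6-fold lower number from compound 2 to compound 4 (0.56 log units; beyond the scatter) and an at least 3.4-fold lower number from compound 3 to compound 4 (0.54 log units; beyond the scatter). The last of these steps starts from compound 3, whose reading is a limit of the test and not a number: the limit of > 100000 nM in this assay, at which 1 of the 4 values shown sits.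

Compound 4 differs from compound 1 in both the group and where it sits on the ring, and the compounds shown do not tell these two changes apart. How an unsubstituted phenyl, a 4-(trifluoromethyl)phenyl or a longer chain would read in this place in this assay stays open, as does any reason for the step, for which nothing measured is shown here.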